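Ethyl to methyl on the dithiocarbamate nitrogen of compound 2

A few compounds are considered here, and "the series" means these few. Any claim that something is new, unique, unknown or untested is made for them only; others in the source may bear on it.

Compound 1 `Nc1ccccc1NC(=O)c1ccc(CSC(=S)N2CCc3ccccc32)cc1` gives 25.7% in a functional assay on A-375 cells (Homo sapiens) for antiproliferative activity, read by CCK-8 assay, with a stated time of 72 h, tested at 2 uM; a higher number here means a stronger effect of the compound at the concentration tested, a lower number a weaker effect. Among the measured compounds shown here, compound 2 `CCN(Cc1ccncc1)C(=S)SCc1ccc(C(=O)Nc2ccccc2N)cc1` gives 67.2% and stands highest of the two numbers, the nearest being compound 1; the single measured step, a number 41.5 percentage points higher from compound 1 to compound 2 (beyond the scatter), is a large gain and is the only comparison available. Compound 3 `CN(Cc1ccncc1)C(=S)SCc1ccc(C(=O)Nc2ccccc2N)cc1` is not yet measured; its change from compound 2 is hydrogen in place of methyl on a saturated chain carbon bound to an amide-type nitrogen, read one bond further out as ethyl to methyl. For the measured compounds named here, no measured step of this kind exists, and the one step that is known replaces the whole amine rather than trimming one chain carbon, so it bears on compound 3 only loosely. The expected step of a number 7.2 percentage points lower from compound 2 to compound 3 (within the scatter) is therefore small, with no clear direction beyond the scatter and a slight lean downward. Compound 3 is estimated at 60%, with a range from 42% to 76%.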

Compound 3, a percentage reported as inhibition, at one concentration (the size of the read-out at that concentration, not a potency): 31.4%
Compound 3: the middle estimate sits 28.6 percentage points above what was measured; measured number below the stated range.
By their numbers in this assay, from the lowest: compounds 1 and 3 (each within the scatter of the next); then compound 2.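

In this assay the change from ethyl to methyl on the dithiocarbamate nitrogen, a loss of one carbon, gives a number 35.8 percentage points lower from compound 2 to compound 3 (beyond the scatter) and so counts as a large step at this position. With methyl((pyridin-4-yl)methyl)amino in place of 2,3-dihydro-1H-indol-1-yl the series shows a number 5.7 percentage points higher from compound 1 to compound 3 (within the scatter) and so the large gain seen for compound 2 over compound 1 is not carried by the (pyridin-4-yl)methyl group alone, but appears only together with ethyl. Nothing measured on these compounds accounts for the size of this step.

Open, on these data alone, is whether a longer chain such as propyl, or a branched one such as isopropyl, on the same nitrogen keeps or exceeds the number of compound 2. Also open, as far as these compounds go, is whether benzyl in place of (pyridin-4-yl)methyl holds that number with ethyl kept.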